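Methoxy for Iodo on an Arylvinyl Sulfone Ketone

The source may hold more compounds than are shown below. What is called first, only, known or untested is meant among the compounds shown, and "the series" means these compounds.

Compound 1 `Cc1cc(C)cc(/C=C(\C(=O)c2ccc(Cl)cc2)S(=O)(=O)c2ccc(Br)cc2)c1` gives 10000 nM in a functional assay on DU-145 cells (Homo sapiens) for inhibition, read by trypan blue exclusion, with a stated time of 96 h; on this read-out higher numbers stand for weaker inhibition of growth and lower numbers for stronger inhibition of growth.
Compound 2 `O=C(/C(=C\c1ccc(I)cc1)S(=O)(=O)c1ccc(Br)cc1)c1ccc(Br)cc1` gives 1000 nM in this assay.
Compound 3 `COc1ccccc1/C=C(/SCc1ccc(Cl)c(Cl)c1)C(=O)c1ccc(Cl)cc1` gives 10000 nM in this assay.

Among the three measured compounds, compound 2 stands at the lowest number, and so at the strongest inhibition of growth in this assay. Compound 1 sits at a number beyond the scatter higher than compound 2, and compound 3 sits at the same higher number; both of them are separated from compound 2 by more than the usual spread of repeated measurements, so compound 2 is the most potent of the three.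

Compound 4 `COc1ccc(/C=C(\C(=O)c2ccc(Br)cc2)S(=O)(=O)c2ccc(Br)cc2)cc1` has not yet been measured. It keeps the core of compound 2 and differs in a single place: methoxy in place of iodo on an aromatic carbon. Going by the values given here, no measured pair shows this exchange on its own, so the size of the step has to be judged from what the three values show. Both compounds that lack the iodo substituent of compound 2 sit at the higher number, which argues that moving away from iodo weakens inhibition of growth rather than strengthening it.

On that basis compound 4 is expected to give 3000 nM in this assay, with a range from 800 nM to 12000 nM. The expected step is a 3.0-fold higher number from compound 2 to compound 4 (0.48 log units; beyond the scatter), a weakening somewhat beyond the scatter.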

Compound 4, concentration for 50% growth inhibition: 25000 nM
Compound 4: the middle estimate sits 8.3-fold (0.92 log units) below what was measured; the measured number lies above the stated range.
By their numbers in this assay, from the lowest: compound 2; then compounds 1 and 3 (each within the scatter of the next); then compound 4.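

In this assay, replacing iodo with methoxy on an aromatic carbon, para to a large group, produces a large change: a 25-fold higher number from compound 2 to compound 4 (1.40 log units; beyond the scatter). Going by these compounds alone, this is the first direct reading of this position, as no earlier pair differed in one place, and it shows that with the rest of the core of compound 2 held fixed, going from 4-iodophenyl to 4-methoxyphenyl costs inhibition of growth well beyond the scatter. Nothing measured here explains the size of this step, which rests on a single pair.

The compounds shown leave open whether the loss tracks the departure of iodo or the arrival of methoxy, and whether a plain hydrogen, a chlorine or an amine at this position would give a number nearer that of compound 2 or that of compound 4. On these data alone, it also remains open whether the same exchange would carry a step of similar size with a different group on the sulfonyl or the ketone side of the core.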